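The source may report more compounds than this note shows. Statements on the series, on what has been measured and on what is new or still open speak of the compounds shown alone.

Measured compounds:
compound 1 `CC(C)(C)c1cc(NC(=O)Nc2ccc(Nc3ncnc4c3OCCN4)cc2)no1` — 34 nM
compound 2 `Cc1cc(NC(=O)Nc2cc(C(C)(C)C)on2)ccc1Nc1ncnc2c1OCCN2` — 44 nM

In an assay on isolated protein for inhibition of proto-oncogene tyrosine-protein kinase receptor Ret variant V804M (Homo sapiens), read by 33P incorporation, with stated times of 15 min and 40 min (on this read-out higher numbers stand for weaker inhibition and lower numbers for stronger inhibition), compound 2 gives 44 nM, the larger of the two numbers, but a 1.3-fold higher number from compound 1 to compound 2 (0.11 log units; within the scatter) lies within the scatter, so compound 1 and compound 2 are not distinguished. Compound 3 `COc1cc(NC(=O)Nc2cc(C(C)(C)C)on2)ccc1Nc1ncnc2c1OCCN2` differs from compound 2 by methoxy in place of methyl on an aromatic carbon. For the measured compounds named here, the only step at that position is the one from compound 1 to compound 2, which was within the scatter; a step of no greater size is therefore expected in this assay. For compound 3 the expected value is 45 nM with a range from 20 nM to 110 nM. This estimate corresponds to a 1.0-fold higher number from compound 2 to compound 3 (0.01 log units; within the scatter).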

Compound 3, half-maximal inhibitory concentration: 33 nM
Compound 3: the middle estimate sits 1.4-fold (0.13 log units) above what was measured; low and high end bracket the measured number.
By their numbers in this assay, from the lowest: compounds 3, 1 and 2 (each within the scatter of the next).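

In this assay, methoxy on this aromatic carbon, ortho to a large group, gives a 1.3-fold lower number from compound 2 to compound 3 (0.12 log units; within the scatter) and, against hydrogen, a 1.0-fold lower number from compound 1 to compound 3 (0.01 log units; within the scatter). Hydrogen, methyl and methoxy at this position are therefore not distinguished, and the hydrogen-bond acceptor that enters with methoxy leaves no step beyond the scatter. Nothing available explains this result.

Going by these compounds, whether an amine, a carboxylic acid or a longer chain such as butoxy would also stay within the scatter remains open. Also open, on these data alone, is whether this flat picture holds for the other forms of the kinase.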